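The compounds below may be only part of what the source reports. "The series", "measured", "known", "first", "only" and "open" are said of these compounds alone.

Measured in a functional assay on HCT-116 cells (Homo sapiens) for inhibition, read by CCK-8 assay, with a stated time of 48 h; a higher number here means a weaker inhibitor, a lower number a stronger inhibitor:
compound 1 `COc1cc(-c2cc3nccc(-c4cc(OC)c(OC)c(OC)c4)n3n2)cc(OC)c1OC`: > 10000 nM
compound 2 `COc1cc(-c2ccnc3cc(-c4cn(CO)c5ccccc45)nn23)cc(OC)c1OC`: 128 nM
compound 3 `COc1cc(-c2ccnc3cc(-c4cccc(C#N)c4)nn23)cc(OC)c1OC`: > 10000 nM

Compound 3 has no number on this read-out: its > 10000 nM is a limit of the assay. Compound 1 gives > 10000 nM, which is also a limit. Only compound 2 gives a number, at 128 nM. For the measured compounds named here, the series so far is marked by the limit of > 10000 nM in this assay, at which 2 of the 3 values shown sit.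

The next compound is compound 4 `COc1cc(-c2ccnc3cc(-c4ccc(C(F)(F)F)cc4)nn23)cc(OC)c1OC`. It carries 4-(trifluoromethyl)phenyl in place of 3-cyanophenyl on an aromatic carbon of a five-membered aromatic ring with 2 nitrogen, next to the ring nitrogen: 4-(trifluoromethyl)phenyl in place of 3-cyanophenyl on an aromatic carbon. Going by the values given here, no measured pair differs in one place only, so the size of this change in this assay has no direct precedent.

The expectation rests on compound 3, which sits at > 10000 nM, a limit. One phenyl group replaces another, and no gain in potency is expected from that alone. The expected size is a number no higher from compound 3 to compound 4 (the limit leaves the size open), estimated as nothing beyond the scatter and in neither direction. Another limit is expected to be the most likely reading. For compound 4 the estimate is 10000 nM, with an expected range of 2000 nM to 30000 nM.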

Compound 4, half-maximal inhibitory concentration: 1860 nM
Estimate against measurement, compound 4: 5.4-fold (0.73 log units) above; measured number below the stated range.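

In this assay, for the compounds shown here, the change from 3-cyanophenyl to 4-(trifluoromethyl)phenyl gives an at least 5.3-fold lower number from compound 3 to compound 4 (0.73 log units; beyond the scatter), the first reading of a one-place change at this aromatic carbon of the five-membered ring. It shows that the substituted phenyl group at this place decides whether a measured number appears at all, with the shared remainder of the molecule held constant: compound 4 gives 1860 nM. A phenyl group here does not by itself put a compound at the limit. The true size of the step stays unknown because compound 3 carries a limit rather than a number: the limit of > 10000 nM in this assay, at which 2 of the 4 values shown sit.

The step changes the substituent on the phenyl ring and its place on that ring together, so the compounds shown do not tell which of the two carries the difference. On these data alone, it also remains open how a phenyl ring carrying an amine or a carboxylic acid at this aromatic carbon would read in this assay.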